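The source may hold more compounds than are shown below. What is called first, only, known or untested is meant among the compounds shown, and "the series" means these compounds.

Compound 1 `C=C1C(=O)[C@]23C[C@@]1(O)CC[C@H]2c1ccc(O)c(C)c1[C@@H]3Cn1cc(-c2ccccn2)nn1` and compound 2 `C=C1C(=O)[C@]23C[C@@]1(O)CC[C@H]2c1ccc(O)c(C)c1[C@@H]3Cn1cc(-c2ccc(C(F)(F)F)cc2)nn1` share one core and differ only in the group carried on the triazole ring. In a functional assay on SMMC-7721 cells (Homo sapiens) for cytotoxicity, read by MTT assay, with a stated time of 4 days (on this read-out lower numbers stand for stronger inhibition and higher numbers for weaker inhibition), compound 1 gives 1270 nM, and compound 2 gives 1440 nM. The change between them is 4-(trifluoromethyl)phenyl in place of pyridin-2-yl on an aromatic carbon, and it produces a 1.1-fold higher number from compound 1 to compound 2 (0.05 log units; within the scatter). Compound 3 `C=C1C[C@]23C[C@@]1(O)CC[C@H]2c1cc(Br)c(O)c(C)c1[C@@H]3Cn1cc(-c2ccccn2)nn1` rests on another core; the difference between the two cores is not broken down here. In this assay compound 3 reaches only a limit of the assay, > 20000 nM, which is the limit of > 20000 nM in this assay, at which 1 of the 3 values shown sits. Compound 4 `C=C1C[C@]23C[C@@]1(O)CC[C@H]2c1cc(Br)c(O)c(C)c1[C@@H]3Cn1cc(-c2ccc(C(F)(F)F)cc2)nn1` is not yet measured and arises from compound 3 by the same change, (4-(trifluoromethyl)phenyl in place of pyridin-2-yl on an aromatic carbon). Because a 1.1-fold higher number from compound 1 to compound 2 (0.05 log units; within the scatter) stays within the scatter, an equally small step is expected here, a step that the limit leaves unreadable from compound 3 to compound 4, and the limit of compound 3 suggests that compound 4 will also sit at that limit. Compound 4 is therefore expected to give about 25000 nM in this assay, somewhere between 12000 nM and 60000 nM, most probably reported only as a limit.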

Compound 4, half-maximal inhibitory concentration: 12800 nM
Estimate against measurement, compound 4: 2.0-fold (0.29 log units) above; the measured number falls inside the stated range.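

On the core of compound 3, the change from pyridin-2-yl to 4-(trifluoromethyl)phenyl on the triazole ring gives in this assay an at least 1.5-fold lower number from compound 3 to compound 4 (0.19 log units; that floor lies within the scatter). Compound 3 is reported only as a limit of the assay, > 20000 nM. The result shows that compound 4 gives a measured number on this core and that the floor of the step, like the step on the first core, lies within the scatter, but it does not show that the change carries over unaltered from one core to the other: the same change on two cores in this assay, a 1.1-fold higher number (0.05 log units; within the scatter) from compound 1 to compound 2 and an at least 1.5-fold lower number (0.19 log units; that floor lies within the scatter) from compound 3 to compound 4; the limit leaves it open whether they differ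

The compounds shown leave open how a different group on the triazole ring, such as an amine or a carboxylic acid, would fare on either core. They also leave open how the bromine and the carbonyl, the two features that set the cores apart, each bear on the numbers in this assay.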